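A few compounds are considered here, and "the series" means these few. Any claim that something is new, unique, unknown or untested is made for them only; others in the source may bear on it.

Three compounds share one core. In a functional assay on BT-549 cells (Homo sapiens) for cytotoxicity, read by sulforhodamine B assay, with a stated time of 48 h, tested at 1 uM (on this read-out lower numbers stand for a stronger effect and higher numbers for a weaker effect at the one concentration tested), compound 1 `COc1cc(-c2cc(/C=C/C(=O)c3ccc(Cl)c(Cl)c3)[nH]n2)cc(OC)c1OC` gives 92%, compound 2 `COc1ccc(C(=O)/C=C/c2cc(-c3cc(OC)c(OC)c(OC)c3)n[nH]2)cc1OC` gives 76%, and compound 3 `COc1ccc(C(=O)/C=C/c2cc(-c3cc(OC)c(OC)c(OC)c3)n[nH]2)cc1` gives 93%. Compound 2 stands lowest of the three: the steps of a number 16 percentage points lower from compound 1 to compound 2 (beyond the scatter) and a number 17 percentage points higher from compound 2 to compound 3 (beyond the scatter) both lie beyond the scatter, while the step of a number 1 percentage points higher from compound 1 to compound 3 (within the scatter) lies within it. Compound 4 `COc1cc(C(=O)/C=C/c2cc(-c3cc(OC)c(OC)c(OC)c3)n[nH]2)cc(OC)c1OC` differs from compound 2 by methoxy in place of hydrogen on an aromatic carbon, on an aromatic carbon ortho to a methoxy group and meta to a large group. Going by the values given here, only the step from compound 2 to compound 3 bears on this, where a methoxy left and the number rose; here a methoxy enters, so a modest fall or no change beyond the scatter is expected in this assay. Compound 4 is estimated at 68%, between 50% and 88%. That estimate means a step of a number 8 percentage points lower from compound 2 to compound 4 (within the scatter).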

Compound 4, a percentage reported as activity, at one concentration (the size of the read-out at that concentration, not a potency): 85%
For compound 4 the middle estimate is 17 percentage points below the measured one, within the range that was stated.
By their numbers in this assay, from the lowest: compounds 2, 4, 1 and 3 (each within the scatter of the next, the first and the last beyond it).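

In this assay, the step of a number 9 percentage points higher from compound 2 to compound 4 (within the scatter) shows that a methoxy entering on this aromatic carbon, ortho to a methoxy group and meta to a large group, leaves the number within the scatter. The earlier step of a number 17 percentage points higher from compound 2 to compound 3 (beyond the scatter) had shown only that the methoxy lost there counted beyond the scatter, and this second place on the ring does not repeat that. Nothing available explains the result.

On these data alone, whether a hydroxyl or an amine on this carbon would move the number beyond the scatter stays open.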